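Two dimethoxyphenyl sulfonamides and a ring-bound analogue

A few compounds are considered here, and "the series" means these few. Any claim that something is new, unique, unknown or untested is made for them only; others in the source may bear on it.

Of the compounds shown here, three sharing the same dichlorinated enone fragment have been measured in a functional assay on HL-60 cells (Homo sapiens) for cytotoxicity, read by luminescence; a higher number here means a weaker inhibitor, a lower number a stronger inhibitor. Compound 1 `C=C(CC)C(=O)c1ccc(OCC(=O)NCCNS(=O)(=O)c2ccc(OC)c(OC)c2)c(Cl)c1Cl` gives 3360 nM. Compound 2 `C=C(CC)C(=O)c1ccc(OCC(=O)NCCNS(=O)(=O)c2ccc(OC)cc2OC)c(Cl)c1Cl` gives 2790 nM in this assay. Compound 3 `C=C(CC)C(=O)c1ccc(OCC(=O)NC2CCN(S(=O)(=O)c3ccc(OC)c(OC)c3)CC2)c(Cl)c1Cl` gives 1310 nM in this assay, the lowest of the three numbers, with steps to compound 2 and compound 1 that lie beyond the scatter.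

The change from compound 1 to compound 2 is 2,4-dimethoxyphenyl in place of 3,4-dimethoxyphenyl on a sulfonyl sulfur, and it produced a 1.2-fold lower number from compound 1 to compound 2 (0.08 log units; within the scatter). The difference between the core of compound 1 and the core of compound 3 is not broken down here.

Compound 4 `C=C(CC)C(=O)c1ccc(OCC(=O)NC2CCN(S(=O)(=O)c3ccc(OC)cc3OC)CC2)c(Cl)c1Cl` has not yet been measured in this assay. Its relation to compound 3 is 2,4-dimethoxyphenyl in place of 3,4-dimethoxyphenyl on a sulfonyl sulfur. This is the same kind of change as that from compound 1 to compound 2, but the surroundings differ: in compound 1 and compound 2 the sulfonyl sulfur is joined to a sulfonamide nitrogen, while in compound 3 and compound 4 it is joined to a sulfonamide nitrogen in a ring.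

For the measured compounds named here, since the one measured instance of this change gave a step within the scatter, compound 4 is expected to sit close to compound 3, with a step of about a 1.1-fold lower number from compound 3 to compound 4 (0.06 log units; within the scatter) estimated because a 1.2-fold lower number from compound 1 to compound 2 (0.08 log units; within the scatter). Compound 4 is therefore estimated at 1150 nM in this assay, with a likely range from 500 nM to 2800 nM.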

Compound 4, half-maximal inhibitory concentration: 860 nM
Compound 4: middle estimate off by 1.3-fold (0.13 log units), on the high side, within the range that was stated.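

In this assay, putting 2,4-dimethoxyphenyl in place of 3,4-dimethoxyphenyl on a sulfonyl sulfur joined to a sulfonamide nitrogen in a ring gave a 1.5-fold lower number from compound 3 to compound 4 (0.18 log units; within the scatter), so this read-out does not separate compound 4 from compound 3. The change therefore carried from the core of compound 1 to the core of compound 3 without a detectable difference in its size, and on both cores it stayed too small to be read as a real effect: the same change on two cores in this assay, a 1.2-fold lower number (0.08 log units; within the scatter) from compound 1 to compound 2 and a 1.5-fold lower number (0.18 log units; within the scatter) from compound 3 to compound 4, 1.3-fold (0.10 log units) apart, within the scatter of two such steps. For the compounds shown here, this shows only that the change had no effect beyond the scatter on these two cores; with two pairs, it neither establishes a small real gain from the 2,4-dimethoxyphenyl group nor shows that the same result would hold on any other core.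

As far as these compounds go, all four compounds carry a dimethoxyphenyl group on the sulfonyl sulfur and the same dichlorinated enone fragment, so it remains open whether a different group there, such as a trifluoromethyl, a nitrile or an amine on the phenyl ring, would give a step beyond the scatter. From the compounds shown here alone, it is also open whether the result would hold with a longer chain in place of the ethyl group on the enone.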